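A few compounds are considered here, and "the series" means these few. Any claim that something is new, unique, unknown or untested is made for them only; others in the source may bear on it.

Compound 1 `COc1cc2c(/C=C3/C(=O)Nc4ccc(O)cc43)c(Cl)n(Cc3cc(OC)c(OC)c(OC)c3)c2cc1C`: 11500 nM
Compound 2 `O=C1Nc2ccccc2/C1=C\c1c(Cl)n(Cc2ccccc2)c2ccccc12`: 32400 nM
Compound 3 `O=C1/C(=C/c2c(Cl)[nH]c3ccccc23)c2ccccc2N1Cc1ccccc1`: 61700 nM

These three compounds were tested in a functional assay on cells (Melanoma cell, Homo sapiens) for cytotoxicity, with a stated time of 48 h; a lower number here means a stronger inhibitor of growth, a higher number a weaker inhibitor of growth. Compound 2 gives 32400 nM there, the second highest of the three numbers. Its nearest neighbour is compound 3 at 61700 nM, a gap that lies within the usual scatter, so the two cannot be told apart. Compound 1, with 11500 nM, sits beyond the scatter from compound 2 and is the lower number of that pair.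

Compound 4 `O=C1Nc2ccccc2/C1=C\c1c(Cl)n(CCCc2ccccc2)c2ccccc12` is not yet measured. It differs from compound 2 in one place: phenethyl in place of phenyl on a saturated chain carbon bound to an aromatic nitrogen. The same difference, cut one bond further out, reads benzyl to 3-phenylpropyl. Among the compounds with values here, no measured pair shows this kind of change, so there is nothing to measure a step against. In this assay the expectation is therefore a step no larger than the scatter, in no firm direction. For compound 4 the estimate is 30000 nM, with a range from 12000 nM to 80000 nM, which is expected to mean a step of a 1.1-fold lower number from compound 2 to compound 4 (0.03 log units; within the scatter).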

Compound 4, concentration for total growth inhibition: 67600 nM
Compound 4: the middle estimate sits 2.3-fold (0.35 log units) below what was measured, and the stated range covers the measured number.
By their numbers in this assay, from the lowest: compound 1; then compounds 2, 3 and 4 (each within the scatter of the next, the first and the last beyond it).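

Within the data shown here, compound 2 and compound 4 form the first pair here that differs in one place only, so the group on the saturated chain carbon bound to the aromatic nitrogen can now be read directly. In this assay, changing benzyl to 3-phenylpropyl keeps the same aromatic ring but adds chain carbons, and this gives a 2.1-fold higher number from compound 2 to compound 4 (0.32 log units; beyond the scatter), a modest step towards weaker growth inhibition. So at this position, the longer chain brought no gain, but no measurement on hand explains the step.

One pair cannot show whether the number keeps rising as the chain grows, or whether the same step would appear on the more heavily substituted core of compound 1. It also leaves open how an amine or a carboxylic acid at the end of the chain, in place of the phenyl ring, would read.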